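The source may report more compounds than this note shows. Statements on the series, on what has been measured and on what is new or still open speak of the compounds shown alone.

The measured compounds in a functional assay on cells for positive allosteric modulation of G-protein coupled receptor 68 (Homo sapiens), read by a luciferase reporter and cAMP accumulation, with a stated time of 30 min, at pH 6.8 and pH 8.3, in the presence of a further agent that is not named here (a lower number here means a less potent compound, a higher number a more potent compound, by a factor of ten per unit of this negative logarithm), are:

Compound 1 `COc1cccc(-c2nc(N)nc(NCc3ccccc3)n2)c1CO`: 4.16
Compound 2 `COc1cccc(CO)c1-c1nc(N)nc(NCc2ccccc2)n1`: "not active" (no number reported)
Compound 3 `Nc1nc(NCc2ccccc2F)nc(-c2ccccc2CO)n1`: 4.27

Compound 3 and compound 1 give numbers that lie within the usual scatter of each other, so neither can be set above the other. For the measured compounds named here, compound 2 is reported as not active in this assay and gives no number, so only two numbers are known. No pair of these compounds differs in one place alone, so no single step has been measured.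

Compound 4 `COc1ccccc1CNc1nc(N)nc(-c2ccccc2CO)n1` is not yet measured. It differs from compound 3 in one place: methoxy in place of fluoro on an aromatic carbon. Going by the values given here, nothing among the measured compounds shows what such a change does here, and the two known numbers sit close together near the low end of what this assay resolves.

Among the compounds with values here, with no measured step to lean on, the expected change from compound 3 to compound 4 is a number 0.07 log units lower from compound 3 to compound 4 (within the scatter), a shift that is not expected to pass beyond the scatter in either direction. Compound 4 is therefore expected to give about 4.2 in this assay, within a range from 3.6 to 4.8.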

Compound 4, negative logarithm of the antagonist equilibrium constant: 3.99
Compound 4: middle estimate off by 0.21 log units, on the high side, and the stated range covers the measured number.
By their numbers in this assay, from the lowest: compounds 4, 1 and 3 (each within the scatter of the next).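

In this assay, for the compounds shown here, the change from 2-fluorophenyl to 2-methoxyphenyl is the first single step available in this set, and it gives a number 0.28 log units lower from compound 3 to compound 4 (within the scatter). At this place on the aromatic ring, ortho to a large group, methoxy can therefore stand in for fluoro without a shift that can be told apart from the ordinary spread of repeat measurements, and compound 4 still gives a number rather than a "not active" report. No measurement of any property of these two groups is available to bear on this step.

On these data alone, only these two groups have been compared at this position, so it remains open whether an amine, a carboxylic acid or a longer chain such as butoxy would leave the number as little changed. As far as these compounds go, the same fluoro-to-methoxy change also remains untested at the other carbons of this ring.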